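Same ring swap on two cores, read in mouse microsomes

The compounds below may be only part of what the source reports. "The series", "measured", "known", "first", "only" and "open" are said of these compounds alone.

Compound 1, `CNc1ccc2cc(-c3cc(Cl)cc(Cl)c3)c(N)nc2c1`: < 10 mL/min/kg
Compound 2, `Nc1nc2cc(N3CCCC3)ccc2cc1-c1cc(Cl)cc(Cl)c1`: 320 mL/min/kg
Compound 3, `CNc1ccc2cc(-c3cn(C)c4ccccc34)c(N)nc2c1`: 41 mL/min/kg

All three compounds were measured in an ADME assay on microsomes from liver (Mus musculus) for metabolic stability, read by HPLC, with a stated time of 4 h; on this read-out lower numbers stand for slow clearance and higher numbers for fast clearance. For compound 1 the value is a limit of the measurement rather than a number, (the limit of < 10 mL/min/kg in this assay, at which 1 of the 3 values shown sits). Compound 2 carries a (pyrrolidin-1-yl in place of methylamino on an aromatic carbon), and that change gives an at least 32-fold higher number from compound 1 to compound 2 (1.50 log units; beyond the scatter). Compound 3 carries a different core; the difference between the two cores is not broken down here. Among the two numbers shown, compound 3 has the lower one, and compound 2 sits above it by a gap that is beyond the usual scatter.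

Compound 4, `Cn1cc(-c2cc3ccc(N4CCCC4)cc3nc2N)c2ccccc21`, has not yet been measured. Within the data shown here, it differs from compound 3 by a (pyrrolidin-1-yl in place of methylamino on an aromatic carbon), which is the same change as the one from compound 1 to compound 2, and it sits at the same place on the shared core. On compound 1 that change produced a large rise in clearance, and the size of that rise can only be given as a lower bound because the starting value is a limit. Compound 3 starts from a measured number, so the expected step can be stated more fully. Applying the same change to compound 3, the expected step is an 8.5-fold higher number from compound 3 to compound 4 (0.93 log units; beyond the scatter), resting on an at least 32-fold higher number from compound 1 to compound 2 (1.50 log units; beyond the scatter) seen with the other core. Compound 4 is therefore estimated to give 350 mL/min/kg, with a likely range from 150 mL/min/kg to 900 mL/min/kg.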

Compound 4, clearance: > 500 mL/min/kg
Compound 4 gave a limit, no number; the forecaster's own chance of this, stated with the estimate: 5%; middle value at least 1.4-fold (0.15 log units) from the limit.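

In this assay, putting pyrrolidin-1-yl in place of methylamino on an aromatic carbon gives, on the core of compound 3, an at least 12-fold higher number from compound 3 to compound 4 (1.08 log units; beyond the scatter), so the direction of the change seen on the core of compound 1 carries over in this second pair. From the compounds shown here alone, compound 4 gives > 500 mL/min/kg, which is a limit of the assay and not a number, so the true size of this step stays unknown. The two pairs therefore show that the rise in clearance appears on both cores, but they do not show whether it has the same size on each: the same change on two cores in this assay, an at least 32-fold higher number (1.50 log units; beyond the scatter) from compound 1 to compound 2 and an at least 12-fold higher number (1.08 log units; beyond the scatter) from compound 3 to compound 4; the limit leaves it open whether they differ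

The compounds shown leave open whether the rise belongs to the pyrrolidin-1-yl ring in particular or would also come with an open-chain amine such as dimethylamino, or with a six-membered ring such as piperidin-1-yl or morpholin-4-yl. Among these compounds, with only two pairs to go on, they also leave open whether the same direction would hold on a third core, so a rule for the whole series cannot be drawn from them.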